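The compounds below may be only part of what the source reports. "The series", "measured", "known", "first", "only" and "open" are said of these compounds alone.

Measured compounds in a functional assay on HT cells (Homo sapiens) for antiproliferative activity, read by fluorescence, with a stated time of 72 h; on this read-out higher numbers stand for weaker inhibition of growth and lower numbers for stronger inhibition of growth:

- compound 1 `CC(C)c1n[nH]c2c(NCc3ccc(-c4ccccn4)cc3)nc(SCCO)nc12` gives 48 nM
- compound 2 `CC(C)c1n[nH]c2c(NCc3ccc(-c4ccccn4)cc3)nc(SCC(O)C(F)(F)F)nc12` gives 690 nM
- compound 3 `CC(C)c1n[nH]c2c(NCc3ccc(-c4ccccn4)cc3)nc(SCC(C)(C)O)nc12` gives 507 nM

Compound 2 stands at the highest of the three numbers in this assay. Compound 3 sits nearest, with the pair within the scatter a 1.4-fold lower number from compound 2 to compound 3 (0.13 log units; within the scatter), while compound 1 lies furthest below a 14-fold higher number from compound 1 to compound 2 (1.16 log units; beyond the scatter).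

Compound 4 `CC(C)c1n[nH]c2c(NCc3ccc(-c4ccccn4)cc3)nc(SCCC(N)=O)nc12` is not yet measured. It differs from compound 2 at the saturated chain carbon bound to a sulfur: carbamoylmethyl in place of 2,2,2-trifluoro-1-hydroxyethyl on a saturated chain carbon bound to a sulfur. Among the compounds with values here, two measured steps bear on this change. Building out the carbon that carries the hydroxyl in compound 1 gave a large rise in both cases, a 14-fold higher number from compound 1 to compound 2 (1.16 log units; beyond the scatter) and an 11-fold higher number from compound 1 to compound 3 (1.02 log units; beyond the scatter), so branching at that carbon is costly here. Within the data shown here, compound 4 removes the trifluoromethyl and carries an unbranched carbamoylmethyl instead, but no measured pair shows what exchanging a hydroxyl for an amide does on this chain. The account therefore expects a moderate drop in the number for compound 4, a 3.1-fold lower number from compound 2 to compound 4 (0.50 log units; beyond the scatter), without a full return to the level of compound 1. The estimate for compound 4 is 220 nM, between 60 nM and 800 nM.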

Compound 4, concentration for 50% growth inhibition: 120 nM
Beside the measured number, compound 4's estimate is 1.8-fold (0.26 log units) above it, within the range that was stated.
By their numbers in this assay, from the lowest: compound 1; then compound 4; then compounds 3 and 2 (each within the scatter of the next).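

Carbamoylmethyl in place of either branched group on the saturated chain carbon bound to a sulfur gives a 5.8-fold lower number from compound 2 to compound 4 (0.76 log units; beyond the scatter) and a 4.2-fold lower number from compound 3 to compound 4 (0.63 log units; beyond the scatter), so this position is not tied to a hydroxyl for a much lower number. Among the compounds shown, the two unbranched chains give lower numbers than the two branched ones, but the two unbranched chains are not equal: carbamoyl in place of hydroxy gives a 2.5-fold higher number from compound 1 to compound 4 (0.40 log units; beyond the scatter) and leaves the hydroxyl chain ahead of the amide. No measurement at hand explains this order.

The compounds shown leave open whether a carboxylic acid or an amine at the end of the same chain would hold the number near that of compound 1. They also leave open how a longer chain, or a methyl group on the amide nitrogen, would change the number.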